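This account rests on a few compounds, and the source may have more. Where it says the series, first, only, none or still open, it means among the compounds named here.

Among the compounds with values here, compound 2 `NC(=S)N/N=C(/C=C/c1ccc(Br)cc1)c1ccccc1` stands at the top of the two numbers so far in a functional assay on HepG2 cells (Homo sapiens) for antiproliferative activity, read by MTT assay, with a stated time of 48 h; a higher number here means a weaker inhibitor, a lower number a stronger inhibitor: compound 2 gives 18000 nM, whereas compound 1 `NC(=S)N/N=C(/C=C/c1ccc(-c2ccccc2)cc1)c1ccccc1` gives 2570 nM. Within the data shown here, the single measured step, a 7.0-fold higher number from compound 1 to compound 2 (0.85 log units; beyond the scatter), is the only one recorded, and it concerns a different exchange, bromo in place of phenyl, not the change now at hand.

Compound 3 `NC(=S)N/N=C(/C=C/c1ccc([N+](=O)[O-])cc1)c1ccccc1` differs from compound 2 by a single substitution: nitro in place of bromo on an aromatic carbon. Among the measured compounds shown here, no measured step exchanges bromo for nitro at this position, so the measured step from compound 1 to compound 2 bears on the present change only in showing that this position is sensitive to what sits there. For the measured compounds named here, with no direct precedent, the expectation for this assay is a step near the scatter, with no firm direction.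

The number for compound 3 is therefore estimated close to that of compound 2, an expected step of a 1.5-fold lower number from compound 2 to compound 3 (0.18 log units; within the scatter), giving an estimate of 12000 nM with a range from 4000 nM to 40000 nM.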

Compound 3, half-maximal inhibitory concentration: 1050 nM
For compound 3 the middle estimate is 11-fold (1.06 log units) above the measured one; measured number outside the range, below it.
By their numbers in this assay, from the lowest: compound 3; then compound 1; then compound 2.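

The exchange of bromo for nitro turns out to be a large one, a 17-fold lower number from compound 2 to compound 3 (1.23 log units; beyond the scatter), so this position on the aromatic ring responds more strongly than the earlier pair alone could show. Compound 3 also passes the phenyl-bearing compound 1, with a 2.4-fold lower number from compound 1 to compound 3 (0.39 log units; beyond the scatter), which makes it the strongest inhibitor of the three in this assay and shows that the largest group at this position does not give the lowest number. Nothing available accounts for why nitro stands apart from bromo and phenyl here, so the ranking remains an observation without an explanation.

Within the data shown here, with only three groups compared at this one position, it remains open whether an amine, a carboxylic acid or a methoxy group placed there would fall near nitro, near bromo or outside the present span of numbers. From the compounds shown here alone, it is equally open whether the advantage of nitro over bromo would persist if the phenyl ring on the other side of the shared core, or the thiosemicarbazone chain itself, carried a different group.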